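Phenyl for Isobutyl on a Saturated Ring Carbon

The source may hold more compounds than are shown below. What is called first, only, known or untested is meant among the compounds shown, and "the series" means these compounds.

Compound 1 `CCCCCCC[C@H]1C[C@H](Br)CCN1S(=O)(=O)c1ccc(C)cc1` reaches only a limit in a functional assay on SW1573 cells (Homo sapiens) for antiproliferative activity, read by sulforhodamine B assay, with a stated time of 48 h (a lower number here means a stronger inhibitor of growth, a higher number a weaker inhibitor of growth), reported as > 100000 nM. Going by the values given here, compound 2 `Cc1ccc(S(=O)(=O)N2CCC(Cl)=CC2CC(C)C)cc1` is the one compound with an actual number, and in this assay compound 2 gives 31000 nM. Compound 3 `Cc1ccc(S(=O)(=O)N2CCC(Cl)=CC2c2ccccc2)cc1` differs from compound 2 by phenyl in place of isobutyl on a saturated ring carbon. Among the compounds with values here, no measured pair shows such a change, so the direction is open; a modest shift in this assay in either direction is expected, with some chance of a limit. Compound 3 is thus expected to give 25000 nM, between 6000 nM and 100000 nM. The expected step is a 1.2-fold lower number from compound 2 to compound 3 (0.09 log units; within the scatter).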

Compound 3, concentration for 50% growth inhibition: 16000 nM
Beside the measured number, compound 3's estimate is 1.6-fold (0.19 log units) above it; the measured number falls inside the stated range.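

In this assay, the saturated ring carbon next to the ring nitrogen carries either phenyl or isobutyl with no change that can be told from scatter: the exchange gives a 1.9-fold lower number from compound 2 to compound 3 (0.29 log units; within the scatter). Going by these compounds alone, this is the first step that can be read at this position, so an aromatic ring of six carbons and a branched chain serve alike here. Neither compound in the pair reaches the ceiling of the assay: the limit of > 100000 nM in this assay, at which 1 of the 3 values shown sits.

On these data alone, whether an amine, a carboxylic acid or a methoxyphenyl group on this carbon would move the number beyond the scatter remains open. So does whether any group here can reach far lower numbers in this assay.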